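The compounds below may be only part of what the source reports. "The series", "measured", "known", "first", "only" and "open" are said of these compounds alone.

Compound 1 `COc1ccc(C2=NN(C(=O)c3cccnc3)C(c3cn(C)c4ccc(Br)cc34)C2)cc1` gives > 300000 nM in an ADME assay on HEK-293T cells (Homo sapiens) for cytotoxicity, read by MTT assay, with a stated time of 48 h (on this read-out lower numbers stand for higher toxicity in this test and higher numbers for lower toxicity in this test), which is a limit of the assay. Compound 2 `COc1ccc(C2=NN(C(=O)c3cccnc3)C(c3cn(C)c4ccc(Br)cc34)C2)cc1OC` gives > 300000 nM in this assay, again a limit of the assay. Compound 3 `COc1ccc2c(c1)c(C1CC(c3ccccc3)=NN1C(=O)c1cccnc1)cn2C` gives > 300000 nM in this assay, also a limit of the assay.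

From compound 1 to compound 2 the change is methoxy in place of hydrogen on an aromatic carbon, and the resulting step that the two limits leave unreadable from compound 1 to compound 2 cannot be sized. The difference between the core of compound 1 and that of compound 3 is not broken down here. Compound 4 `COc1ccc2c(c1)c(C1CC(c3ccccc3)=NN1C(=O)c1ccc(OC)nc1)cn2C` differs from compound 3 by methoxy in place of hydrogen on an aromatic carbon, the same kind of change: in compound 2 it sits on a six-membered aromatic ring of carbon only, ortho to a methoxy group and meta to a large group, whereas in compound 4 it sits on a six-membered aromatic ring with 1 nitrogen, next to the ring nitrogen and para to a large group. Going by the values given here, all three measured values sit at the limit of > 300000 nM in this assay, at which 3 of the 3 values shown sit, so no step of this change is readable. Compound 4 is therefore expected to remain at the limit, an estimated step of a number no higher from compound 3 to compound 4 (the limit leaves the size open), resting on (the limit of > 300000 nM in this assay, at which 3 of the 3 values shown sit). The estimate for compound 4 is 300000 nM, expected between 150000 nM and 300000 nM.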

Compound 4, half-maximal cytotoxic concentration: > 300000 nM
Compound 4 was reported as a limit; the forecaster's own chance of this, stated with the estimate: 85%; the middle value sits exactly at the limit.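

Going by these compounds alone, compound 4 gives > 300000 nM, a limit of the assay, so no step from compound 3 to it can be read. The compounds shown leave open whether methoxy in place of hydrogen changes the half-maximal cytotoxic concentration at all: the limit of > 300000 nM in this assay, at which 4 of the 4 values shown sit.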